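Changing the Side Group on a Shared Core

This account rests on a few compounds, and the source may have more. Where it says the series, first, only, none or still open, it means among the compounds named here.

In a functional assay (aorta) with Rattus norvegicus as the target (on this read-out higher numbers stand for an effect only at larger amounts of compound and lower numbers for an effect already at smaller amounts), compound 1 `COc1ccc(-c2nc(CN(C)C)sc2-c2ccc(OC)cc2)cc1` gives 8.4 uM and compound 2 `COc1ccc(-c2nc(CNC(=O)c3cccnc3)sc2-c2ccc(OC)cc2)cc1` gives 8.2 uM, so compound 2 stands level with compound 1. Compound 3 `COc1ccc(-c2nc(C(=O)N(C)C)sc2-c2ccc(OC)cc2)cc1` brings a further change to the group on the shared core: dimethylcarbamoyl in place of (((pyridin-3-yl)carbonyl)amino)methyl on an aromatic carbon. Among the compounds with values here, the one measured step that bears on it, a 1.0-fold lower number from compound 1 to compound 2 (0.01 log units; within the scatter), also altered this side group and stayed within the scatter. No shift beyond the scatter is therefore expected in this assay, and the expected step is a 1.0-fold lower number from compound 2 to compound 3 (0.01 log units; within the scatter). A single step is thin evidence, so the range is kept wide. For compound 3 the estimated value is 8 uM, with an expected range of 3 uM to 22 uM.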

Compound 3, concentration for half-maximal effect: 3 uM
Beside the measured number, compound 3's estimate is 2.7-fold (0.43 log units) above it, and the stated range covers the measured number.
By their numbers in this assay, from the lowest: compound 3; then compounds 2 and 1 (each within the scatter of the next).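

Both a 2.7-fold lower number from compound 2 to compound 3 (0.44 log units; beyond the scatter) and a 2.8-fold lower number from compound 1 to compound 3 (0.45 log units; beyond the scatter) lie beyond the scatter in this assay and are modest, so this position on the shared core does respond to its side group, which the earlier swap did not show. The step from compound 1 keeps the dimethylamino nitrogen and turns the carbon linking it to the ring into a carbonyl, and that one change is enough for a shift.

On these data alone, whether a carboxylic acid or a longer chain at this position would go further remains open. Nothing at hand explains the shift.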